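Swapping an aryl group on a five-membered ring

This account rests on a few compounds, and the source may have more. Where it says the series, first, only, none or still open, it means among the compounds named here.

Of the compounds shown here, two have been measured in an assay on CHO cells for binding affinity to Melanocortin receptor 4 (Homo sapiens); a higher number here means a weaker inhibitor, a lower number a stronger inhibitor. Compound 1 `COc1ccc(-n2nc(Sc3ccc(Cl)cc3)cc(CC[C@@H](C)NC(=O)[C@H]3CNCC[C@@H]3c3ccc(Cl)cc3)c2=O)cc1` gives 2.4 nM, while compound 2 `COc1ccc(-n2nc(Sc3ccc(Cl)cc3)cc(CC[C@@H](C)NC(=O)[C@H]3CNC[C@@H]3c3ccccc3F)c2=O)cc1` gives 160 nM, the highest of the two numbers and well beyond the scatter from compound 1. Compound 3 `COc1ccc(-n2nc(Sc3ccc(Cl)cc3)cc(CC[C@@H](C)NC(=O)[C@H]3CNC[C@@H]3c3ccc(C)cc3)c2=O)cc1` differs from compound 2 in one place: 4-methylphenyl in place of 2-fluorophenyl on a saturated ring carbon. For the measured compounds named here, no measured pair shows this exact change, so the direction is uncertain; a modest shift toward a lower number is expected, a step of a 1.6-fold lower number from compound 2 to compound 3 (0.20 log units; within the scatter). For compound 3 the estimated value in this assay is 100 nM, within a range of 30 nM to 400 nM.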

Compound 3, half-maximal inhibitory concentration: 28 nM
Compound 3: the middle estimate sits 3.6-fold (0.55 log units) above what was measured; measured number outside the range, below it.
By their numbers in this assay, from the lowest: compound 1; then compound 3; then compound 2.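

In this assay, the aryl group on this saturated ring carbon matters on its own: 4-methylphenyl in place of 2-fluorophenyl gives a 5.7-fold lower number from compound 2 to compound 3 (0.76 log units; beyond the scatter) and nothing else changes. Compounds 1 and 2 differ in more than one place, so they could not show this. Nothing shown here explains the step.

From the compounds shown here alone, the change alters both the substituent and its place on the phenyl ring, so which of the two carries the step stays open. Going by these compounds, how 4-fluorophenyl or unsubstituted phenyl would read on this carbon also stays open.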